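A few compounds are considered here, and "the series" means these few. Any claim that something is new, unique, unknown or untested is made for them only; others in the source may bear on it.

Measured so far:
compound 1 `Nc1cc(Oc2ccc(NC(=O)Nc3cccc(C(F)(F)F)c3)cc2)ncn1` — 25 nM
compound 2 `CNc1cc(Oc2ccc(NC(=O)Nc3ccccc3)cc2)ncn1` — 6300 nM
compound 3 `CNc1cc(Oc2ccc(NC(=O)Nc3cccc(C(F)(F)F)c3)c(F)c2F)ncn1` — 20 nM

All three were tested in an assay on isolated protein for inhibition of serine/threonine-protein kinase TNNI3K (Homo sapiens); on this read-out lower numbers stand for stronger inhibition and higher numbers for weaker inhibition. Compound 1 stands second highest of the three numbers. Compound 3 is its nearest neighbour, and the two values lie within the usual scatter of repeated measurements, so they cannot be told apart. Compound 2 is far weaker, its number standing well beyond the scatter from compound 1. Compound 4 `CC(C)(O)CNc1cc(Oc2ccc(NC(=O)Nc3cccc(C(F)(F)F)c3)cc2)ncn1` has not yet been measured. It differs from compound 1 in one place: 2-hydroxy-2-methylpropyl in place of hydrogen on a nitrogen on an aromatic ring. Since compound 3 carries a small group on the same nitrogen and gives 20 nM, a substituent there appears tolerated. The step of a 1.2-fold higher number from compound 1 to compound 4 (0.08 log units; within the scatter) is expected to be small, possibly none beyond the scatter. Compound 4 is expected to give about 30 nM, within the range 10 nM to 90 nM.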

Compound 4, half-maximal inhibitory concentration: 40 nM
Compound 4: the middle estimate sits 1.3-fold (0.12 log units) below what was measured; the range from low to high includes it.
By their numbers in this assay, from the lowest: compounds 3, 1 and 4 (each within the scatter of the next); then compound 2.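

The change from hydrogen to 2-hydroxy-2-methylpropyl on this nitrogen gives a 1.6-fold higher number from compound 1 to compound 4 (0.20 log units; within the scatter) in this assay and leaves the two compounds indistinguishable. For the compounds shown here, this is the first comparison here in which only this nitrogen differs, so it shows directly that the position accepts this larger chain with its hydroxyl group without a measurable loss. Nothing available explains this result.

Open, going by these compounds, is whether the hydroxyl matters, which a plain 2-methylpropyl group could test. Also open, on these data alone, is whether a longer chain ending in an amine or a carboxylic acid would be accepted.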